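The source may report more compounds than this note shows. Statements on the series, on what has been measured and on what is new or still open speak of the compounds shown alone.

Compound 1 `Cc1cccc(-n2nncc2CN2C(=O)C3(C(C#N)=C(N)Oc4c3c3nc5ccccc5nc3c3ccccc43)c3ccccc32)c1` gives in a functional assay on HCT-116 cells (Homo sapiens) for antiproliferative activity, read by MTT assay, with a stated time of 48 h (a lower number here means a stronger inhibitor, a higher number a weaker inhibitor), only the limit > 50000 nM, not a number.
Compound 2 `N#CC1=C(N)Oc2c(N)cc3nc4ccccc4nc3c2C12C(=O)N(Cc1cnnn1-c1ccc(F)cc1)c1ccccc12` gives in this assay only the limit > 50000 nM.
Compound 3 `N#CC1=C(N)Oc2c(N)cc3nc4ccccc4nc3c2C12C(=O)N(Cc1cnnn1-c1ccc([N+](=O)[O-])cc1)c1ccccc12` gives in this assay only the limit > 50000 nM.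

Compound 3 therefore stands at the limit, as do both other values shown (the limit of > 50000 nM in this assay, at which 3 of the 3 values shown sit). The next compound, compound 4 `COc1cc(-n2nncc2CN2C(=O)C3(C(C#N)=C(N)Oc4c(N)cc5nc6ccccc6nc5c43)c3ccccc32)c(OC)cc1Cl`, differs from it in one place: 4-chloro-2,5-dimethoxyphenyl in place of 4-nitrophenyl on an aromatic nitrogen. Within the data shown here, the only measured step at that same place, a step that the two limits leave unreadable from compound 2 to compound 3, has both ends at the limit, so its size cannot be read, and no step here tells how large the change to compound 4 should be. With every value shown sitting at the limit (the limit of > 50000 nM in this assay, at which 3 of the 3 values shown sit), compound 4 is expected to stay there as well. Its estimated value in this assay is 60000 nM, within 20000 nM to 200000 nM. That estimate means a step that the limit leaves unreadable from compound 3 to compound 4, expected to stay within the scatter.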

Compound 4, half-maximal inhibitory concentration: > 50000 nM
Compound 4: a limit, no number (the forecaster's own chance of this, stated with the estimate: 85%); the middle value does not contradict the limit.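

Compound 4 gives only a limit, not a number, as do compound 2 and compound 3, and the steps to compound 4 cannot be read. Which group on the aromatic nitrogen, if any, would give a measurable number in this assay remains open.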